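A Sulfonyl Group Replaces the Amide on the Aryl Nitrogen

A few compounds are considered here, and "the series" means these few. Any claim that something is new, unique, unknown or untested is made for them only; others in the source may bear on it.

Of the compounds shown here, three sharing a common core have been measured in a functional assay on 143B cells (Homo sapiens) for antiproliferative activity, read by MTT assay, with a stated time of 48 h; a lower number here means a stronger inhibitor, a higher number a weaker inhibitor. Compound 1 `Cc1cccc(C(=O)Nc2cccc(/C=C/C(=O)c3nc4ccccc4[nH]3)c2)c1` gives 4880 nM, compound 2 `Cc1ccc(C(=O)Nc2cccc(/C=C/C(=O)c3nc4ccccc4[nH]3)c2)cc1` gives 6560 nM, and compound 3 `O=C(/C=C/c1cccc(NS(=O)(=O)c2cccc(Cl)c2)c1)c1nc2ccccc2[nH]1` gives 2510 nM. Compound 2 thus has the highest of the three numbers; the step of a 1.3-fold higher number from compound 1 to compound 2 (0.13 log units; within the scatter) lies within the scatter, whereas a 2.6-fold lower number from compound 2 to compound 3 (0.42 log units; beyond the scatter) lies beyond it.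

Compound 4 `Cc1cccc(S(=O)(=O)Nc2cccc(/C=C/C(=O)c3nc4ccccc4[nH]3)c2)c1` has not yet been measured in this assay. It differs from compound 2 in one place: (3-methylphenyl)sulfonyl in place of (4-methylphenyl)carbonyl on a nitrogen on an aromatic ring. Among the measured compounds shown here, two measured steps bear on this change. The step of a 2.6-fold lower number from compound 2 to compound 3 (0.42 log units; beyond the scatter) shows the same carbonyl-to-sulfonyl exchange at this nitrogen, though with a (3-chlorophenyl)sulfonyl group entering, and a 1.9-fold lower number from compound 1 to compound 3 (0.29 log units; within the scatter) shows that exchange starting from a (3-methylphenyl)carbonyl group. Both point toward a lower number. Compound 4 is therefore expected to show a modestly lower number, with an expected step of a 2.3-fold lower number from compound 2 to compound 4 (0.35 log units; beyond the scatter). The estimate for compound 4 is 2900 nM, with a range from 1400 nM to 6000 nM.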

Compound 4, half-maximal inhibitory concentration: 791 nM
Estimate against measurement, compound 4: 3.7-fold (0.56 log units) above; the whole stated range lies above it.
By their numbers in this assay, from the lowest: compound 4; then compounds 3, 1 and 2 (each within the scatter of the next, the first and the last beyond it).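

In this assay the exchange of carbonyl for sulfonyl on the nitrogen, with the 3-methylphenyl group held, gives a 6.2-fold lower number from compound 1 to compound 4 (0.79 log units; beyond the scatter) and stands clearly beyond the scatter, whereas a 1.9-fold lower number from compound 1 to compound 3 (0.29 log units; within the scatter) had left the effect of this exchange within it. Among the compounds shown here, with the sulfonyl held, methyl in place of chloro on an aromatic carbon gives a 3.2-fold lower number from compound 3 to compound 4 (0.50 log units; beyond the scatter) and shows that the substituent on the sulfonyl-bearing aromatic ring also counts, which the earlier compounds could not show. The full replacement of the (4-methylphenyl)carbonyl group by (3-methylphenyl)sulfonyl gives an 8.3-fold lower number from compound 2 to compound 4 (0.92 log units; beyond the scatter) and thus combines a change of linking group with a move of the methyl.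

As far as these compounds go, how a (4-methylphenyl)sulfonyl group, or an amine or a carboxylic acid in place of the methyl, would compare stays open. No measurement shown here offers an explanation for these steps.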